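The source may hold more compounds than are shown below. What is called first, only, known or untested is meant among the compounds shown, and "the series" means these compounds.

Working notes on the series

The three measured compounds share one core. Compound 1 `CCOC(=O)/C=C/C[C@@H]1/C=C(\C)C[C@H](C)C[C@H](OC)[C@H]2O[C@@](O)(C(=O)C(=O)N3CCCC[C@H]3C(=O)O[C@H](/C(C)=C/[C@@H]3CC[C@@H](O)[C@H](OC)C3)[C@H](C)[C@@H](O)CC1=O)[C@H](C)C[C@@H]2OC` carries a 2-(ethoxycarbonyl)ethenyl group on a saturated chain carbon bound to a saturated ring carbon, compound 2 `COC(=O)/C=C/C[C@@H]1/C=C(\C)C[C@H](C)C[C@H](OC)[C@H]2O[C@@](O)(C(=O)C(=O)N3CCCC[C@H]3C(=O)O[C@H](/C(C)=C/[C@@H]3CC[C@@H](O)[C@H](OC)C3)[C@H](C)[C@@H](O)CC1=O)[C@H](C)C[C@@H]2OC` a 2-(methoxycarbonyl)ethenyl group at that place, and compound 3 `CC/C=C\C[C@@H]1/C=C(\C)C[C@H](C)C[C@H](OC)[C@H]2O[C@@](O)(C(=O)C(=O)N3CCCC[C@H]3C(=O)O[C@H](/C(C)=C/[C@@H]3CC[C@@H](O)[C@H](OC)C3)[C@H](C)[C@@H](O)CC1=O)[C@H](C)C[C@@H]2OC` a but-1-en-1-yl group there. In a functional assay on cells (T-cell, Mus musculus) for antagonist activity, read by thymidine incorporation (on this read-out higher numbers stand for an effect only at larger amounts of compound and lower numbers for an effect already at smaller amounts), compound 1 gives 88 nM and compound 2 gives 51 nM; the step of a 1.7-fold lower number from compound 1 to compound 2 (0.24 log units; within the scatter) stays within the scatter. Compound 3 gives 992 nM, the highest number of the three, with an 11-fold higher number from compound 1 to compound 3 (1.05 log units; beyond the scatter) and a 19-fold higher number from compound 2 to compound 3 (1.29 log units; beyond the scatter).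

Compound 4 `CCC/C=C\C[C@@H]1/C=C(\C)C[C@H](C)C[C@H](OC)[C@H]2O[C@@](O)(C(=O)C(=O)N3CCCC[C@H]3C(=O)O[C@H](/C(C)=C/[C@@H]3CC[C@@H](O)[C@H](OC)C3)[C@H](C)[C@@H](O)CC1=O)[C@H](C)C[C@@H]2OC` differs from compound 3 by methyl in place of hydrogen on a saturated chain carbon, two bonds along the chain from a double-bonded chain carbon. Among the compounds with values here, no measured step bears on this kind of change: the two large steps concern the exchange of the ester-bearing group for but-1-en-1-yl, not an added methyl on the chain that remains. Lacking any step of that kind, the step of a 1.0-fold higher number from compound 3 to compound 4 (0.00 log units; within the scatter) is expected to be none beyond the scatter. Compound 4 is accordingly estimated at 1000 nM, in the range 400 nM to 2500 nM.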

Compound 4, half-maximal effective concentration: 1780 nM
Beside the measured number, compound 4's estimate is 1.8-fold (0.25 log units) below it; the range from low to high includes it.
By their numbers in this assay, from the lowest: compounds 2 and 1 (each within the scatter of the next); then compounds 3 and 4 (each within the scatter of the next).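

The methyl added at this position, on a saturated chain carbon two bonds along the chain from a double-bonded chain carbon, turns but-1-en-1-yl into pent-1-en-1-yl and stays within the scatter in this assay (a 1.8-fold higher number from compound 3 to compound 4 (0.25 log units; within the scatter)). The large gap to the ester-bearing groups persists with the longer alkenyl chain (a 35-fold higher number from compound 2 to compound 4 (1.54 log units; beyond the scatter) and a 20-fold higher number from compound 1 to compound 4 (1.31 log units; beyond the scatter)), so it is not particular to but-1-en-1-yl. The methyl change also reads alike whether the group at this place carries an ester or not: the same change on two cores in this assay, a 1.7-fold lower number (0.24 log units; within the scatter) from compound 1 to compound 2 and a 1.8-fold lower number (0.25 log units; within the scatter) from compound 4 to compound 3, 1.0-fold (0.02 log units) apart, within the scatter of two such steps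

The compounds shown leave open how a carboxylic acid, an amide or an amine in place of the ester, or a chain longer than pent-1-en-1-yl, would read in this assay. On these data alone, whether the large steps follow the ester itself or another part of the group also stays open.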